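The source may hold more compounds than are shown below. What is called first, only, known or untested is meant among the compounds shown, and "the series" means these compounds.

Of the compounds shown here, three built on a shared core have so far been tested in a functional assay on RPMI-8226 cells (Homo sapiens) for cytotoxicity, read by sulforhodamine B assay, with a stated time of 48 h, tested at 100 uM; on this read-out higher numbers stand for a weaker effect at the one concentration tested and lower numbers for a stronger effect. Compound 1 `COc1ccc(-c2cc(/C=C/C(=O)c3ccc(N)cc3)[nH]n2)cc1` gives -67% in this assay, compound 2 `COc1cc(-c2cc(/C=C/C(=O)c3ccc(N)cc3)[nH]n2)cc(OC)c1OC` gives -40%, and compound 3 `COc1cc(-c2cc(/C=C/C(=O)c3ccc(Cl)c(Cl)c3)[nH]n2)cc(OC)c1OC` gives -25%. Of these three numbers, compound 3 stands highest, which on this read-out means the weakest effect at the single concentration tested; compound 2 is nearest to it and compound 1 furthest from it. For the measured compounds named here, the one measured step between compounds that differ in a single place is a number 15 percentage points higher from compound 2 to compound 3 (beyond the scatter).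

Compound 4 `COc1ccc(C(=O)/C=C/c2cc(-c3cc(OC)c(OC)c(OC)c3)n[nH]2)cc1` has not yet been measured. It differs from compound 3 in one place: 4-methoxyphenyl in place of 3,4-dichlorophenyl on a carbonyl carbon. Going by the values given here, the only measured step that touches this same carbonyl carbon is the one from compound 2 to compound 3, and that step exchanged a 4-aminophenyl for the 3,4-dichlorophenyl, not a 4-methoxyphenyl, so no measured comparison shows directly what the present exchange will do. Since that one change at this position shifted the number by only a modest amount, a modest shift in this assay is expected here as well, with the direction uncertain. Compound 4 is therefore estimated to give -35%, within a range from -65% to -5%. The expected step is a number 10 percentage points lower from compound 3 to compound 4 (within the scatter).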

Compound 4, a percentage reported as activity, at one concentration (the size of the read-out at that concentration, not a potency): -34%
Estimate against measurement, compound 4: 1 percentage points below; low and high end bracket the measured number.
By their numbers in this assay, from the lowest: compound 1; then compounds 2, 4 and 3 (each within the scatter of the next, the first and the last beyond it).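

For the compounds shown here, exchanging 3,4-dichlorophenyl for 4-methoxyphenyl on the carbonyl carbon gives a number 9 percentage points lower from compound 3 to compound 4 (within the scatter) in this assay, so this second exchange at the position produces no step that can be told from the usual variation between repeats. Compound 4 also stays close to the 4-aminophenyl compound, with methoxy in place of amino on an aromatic carbon giving a number 6 percentage points higher from compound 2 to compound 4 (within the scatter), so it lies within the scatter of both compound 2 and compound 3, even though those two compounds are separated by a step beyond the scatter; the three aromatic groups at this position therefore span only a narrow band of numbers, and 4-methoxyphenyl cannot be ranked against either of the others. No evidence is available to explain why the numbers at this position lie so close together.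

Going by these compounds, it remains open whether something other than a substituted phenyl ring on the carbonyl carbon, such as a pyridine ring, a carboxylic acid on the ring or a longer alkyl chain, would move the number further. On these data alone, each reading also comes from one concentration, so how these compounds compare in potency remains open as well.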